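Ethyl in Place of Bromo: Compound 1 to Compound 3

The compounds below may be only part of what the source reports. "The series", "measured", "known", "first", "only" and "open" are said of these compounds alone.

Compound 1 `CCN1CCN(c2cc(C)c3cc(NC(=O)c4ccc(Br)cc4)ccc3n2)CC1`: 6310 nM
Compound 2 `CCN(CC)CCNc1cc(C)c2cc(NC(=O)c3ccc(Cl)c(Cl)c3)ccc2n1`: 3710 nM

Both numbers come from a functional assay on SK-BR-3 cells (Homo sapiens) for antiproliferative activity, read by MTT assay, with a stated time of 72 h; on this read-out lower numbers stand for stronger inhibition and higher numbers for weaker inhibition. Compound 1 and compound 2 lie within the scatter of each other, so the two values give no order between them. Compound 3 `CCc1ccc(C(=O)Nc2ccc3nc(N4CCN(CC)CC4)cc(C)c3c2)cc1` differs from compound 1 in one place: ethyl in place of bromo on an aromatic carbon. Within the data shown here, no step between measured compounds is known for this change, and no other pair shows it. The step from compound 1 to compound 3 in this assay is therefore expected to be small, a 1.1-fold lower number from compound 1 to compound 3 (0.06 log units; within the scatter), with no direction beyond the scatter. Compound 3 is estimated at 5500 nM, in the range 1500 nM to 20000 nM.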

Compound 3, half-maximal inhibitory concentration: 9850 nM
Compound 3: the middle estimate sits 1.8-fold (0.25 log units) below what was measured; the range from low to high includes it.
By their numbers in this assay, from the lowest: compounds 2, 1 and 3 (each within the scatter of the next, the first and the last beyond it).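

In this assay, among these compounds, the exchange of 4-bromophenyl for 4-ethylphenyl gives a 1.6-fold higher number from compound 1 to compound 3 (0.19 log units; within the scatter) and is the first step read at this position, on an aromatic carbon para to a large group. Putting two carbons where one bromine stood thus leaves the number within the scatter, so this single pair shows no clear effect of the change. No measurement at hand bears on the reason for this result.

As far as these compounds go, whether an amine, a carboxylic acid or a longer alkyl chain at this position would move the number beyond the scatter remains open.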